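The compounds below may be only part of what the source reports. "The series", "measured", "known", "first", "only" and "open" are said of these compounds alone.

Compound 3 `CC(C(=O)NCc1ccc(C(F)(F)F)nc1N1CCCC1)c1ccc(NS(C)(=O)=O)c(F)c1` gives 211 nM in a functional assay on CHO-K1 cells for antagonist activity at transient receptor potential cation channel subfamily V member 1 (Homo sapiens), read by FLIPR (on this read-out higher numbers stand for weaker inhibition and lower numbers for stronger inhibition), the lowest of the three numbers recorded. Compound 1 `CC(C(=O)NCc1ccc(C(F)(F)F)nc1Nc1ccccc1)c1ccc(NS(C)(=O)=O)c(F)c1` gives 1400 nM in this assay, and compound 2 `CC(C(=O)NCc1ccc(C(F)(F)F)nc1N(C)C)c1ccc(NS(C)(=O)=O)c(F)c1` gives 2390 nM. Compound 4 `CC(C(=O)NCc1ccc(C(F)(F)F)nc1N1CCC(CN(C)C)CC1)c1ccc(NS(C)(=O)=O)c(F)c1` differs from compound 3 by 4-((dimethylamino)methyl)piperidin-1-yl in place of pyrrolidin-1-yl on an aromatic carbon; the group sits next to the ring nitrogen, ortho to a large group and meta to a trifluoromethyl group. Among the compounds with values here, two measured steps bear on this: an 11-fold lower number from compound 2 to compound 3 (1.05 log units; beyond the scatter) and a 6.6-fold lower number from compound 1 to compound 3 (0.82 log units; beyond the scatter), both favouring the pyrrolidin-1-yl, whereas a 1.7-fold higher number from compound 1 to compound 2 (0.23 log units; within the scatter). Within the data shown here, compound 4 keeps a non-aromatic ring at this position but makes it six-membered and adds a (dimethylamino)methyl group, a change no measured step covers, so a modest rise in this assay is expected for compound 4, a 2.4-fold higher number from compound 3 to compound 4 (0.37 log units; beyond the scatter). Compound 4 is thus estimated at 500 nM, between 150 nM and 2000 nM.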

Compound 4, half-maximal inhibitory concentration: 426 nM
Beside the measured number, compound 4's estimate is 1.2-fold (0.07 log units) above it; low and high end bracket the measured number.
By their numbers in this assay, from the lowest: compound 3; then compound 4; then compounds 1 and 2 (each within the scatter of the next).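

In this assay, a non-aromatic ring with more heavy atoms than pyrrolidin-1-yl still performs well at this position: 4-((dimethylamino)methyl)piperidin-1-yl costs only a modest step (a 2.0-fold higher number from compound 3 to compound 4 (0.31 log units; beyond the scatter)). It also stays clear of dimethylamino (a 5.6-fold lower number from compound 2 to compound 4 (0.75 log units; beyond the scatter)) and anilino (a 3.3-fold lower number from compound 1 to compound 4 (0.52 log units; beyond the scatter)), so among these compounds the advantage of a non-aromatic ring is not confined to the five-membered one. Nothing measured here accounts for these differences. The compounds shown do not separate the six-membered ring from its (dimethylamino)methyl group, so how an unsubstituted piperidin-1-yl or a morpholin-4-yl would compare remains open.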